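The compounds below may be only part of what the source reports. "The series", "measured", "known", "first", "only" and "open" are said of these compounds alone.

Compound 1 `Cc1cc(-c2nc3c(F)cccc3s2)ccc1N`: 5500 nM
Compound 2 `Nc1ccc(-c2nc3cc(F)ccc3s2)cc1`: < 10 nM
Compound 3 `Cc1cc(-c2nc3ccc(F)cc3s2)ccc1N`: 60300 nM

All values come from a functional assay on NCI-H226 cells (Homo sapiens) for inhibition; a lower number here means a stronger inhibitor of growth, a higher number a weaker inhibitor of growth. Compound 2 gives only a limit, < 10 nM, and not a number; it stands at the limit of < 10 nM in this assay, at which 1 of the 3 values shown sits.

Compound 4 `Nc1ccc(-c2nc3cc(F)ccc3s2)cc1I` has iodo in place of hydrogen on an aromatic carbon of compound 2, ortho to an amino group: iodo in place of hydrogen on an aromatic carbon. Among the compounds with values here, no measured pair isolates this change, so the step in this assay remains a judgement. A moderate step towards weaker growth inhibition is expected, although compound 4 may also report only a limit. The expected size is an at least 4.0-fold higher number from compound 2 to compound 4 (0.60 log units; beyond the scatter). For compound 4 the estimate is 40 nM, with an expected range of 5 nM to 3000 nM.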

Compound 4, concentration for 50% growth inhibition: 10200 nM
The estimate for compound 4 lay 260-fold (2.41 log units) below the measured number; measured number outside the range, above it.
By their numbers in this assay, from the lowest: compounds 1 and 4 (each within the scatter of the next); then compound 3. At a limit, below all of these: compound 2.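

In this assay, iodo in place of hydrogen on an aromatic carbon, ortho to an amino group, gives an at least 1000-fold higher number from compound 2 to compound 4 (3.00 log units; beyond the scatter). Within the data shown here, this is the only measured pair that isolates a single change, and it shows that growth inhibition at this position of compound 2 is not retained with iodo. The step has a limit at one end, so its full size cannot be read: the limit of < 10 nM in this assay, at which 1 of the 4 values shown sits.

From the compounds shown here alone, whether the step is specific to iodo remains open. Chloro or methoxy at this position could show whether smaller or different groups give a comparable rise.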